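The source may hold more compounds than are shown below. What is called first, only, known or untested is meant among the compounds shown, and "the series" means these compounds.

Measured in a functional assay on MCF7 cells (Homo sapiens) for cytotoxicity, read by MTT assay, with a stated time of 48 h; on this read-out lower numbers stand for stronger inhibition and higher numbers for weaker inhibition:
- compound 1 `C/C(=N\NC(=S)Nc1ccc([N+](=O)[O-])cc1)c1ccccn1` (52 nM)
- compound 2 `CC(=NNC(=S)Nc1ccc(Cl)cc1)c1ccccn1` (8.5 nM)

Of these two numbers, compound 2 (8.5 nM) has the lower and compound 1 (52 nM) the higher, a gap beyond the usual scatter. The next entry is compound 3 `CC(=NNC(=S)Nc1ccc([N+](=O)[O-])cc1)c1ccccn1`, not yet measured. It departs from compound 2 by nitro in place of chloro on an aromatic carbon, para to a large group (nitro in place of chloro on an aromatic carbon). Within the data shown here, no step between measured compounds is available to size this change directly. Compound 1 also carries a nitro group, and compound 1 gives the higher number (52 nM), so a rise beyond the scatter is expected in this assay for this change. The expected size is a 5.6-fold higher number from compound 2 to compound 3 (0.75 log units; beyond the scatter) on this estimate. For compound 3 the estimated value is 48 nM (expected range 17 nM to 140 nM).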

Compound 3, half-maximal inhibitory concentration: 52 nM
Estimate against measurement, compound 3: 1.1-fold (0.03 log units) below; the measured number falls inside the stated range.
By their numbers in this assay, from the lowest: compound 2; then compounds 1 and 3 (each within the scatter of the next).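

In this assay, the exchange on an aromatic carbon para to a large group now has a direct measure: nitro in place of chloro gives a 6.1-fold higher number from compound 2 to compound 3 (0.79 log units; beyond the scatter). The earlier pair could not isolate this change, as compounds 1 and 2 differ both in this group and in how the double bond is drawn. The second step, no change at the digits printed from compound 1 to compound 3 (within the scatter), shows no separation in this assay between the form drawn E and the form drawn without a configuration, and the only difference within that pair is: the fact that one of compounds 1 and 3 is drawn with a defined configuration and the other without, at the place where they differ

Whether the higher number is specific to nitro remains open, as other groups at this place, such as an amine, a methoxy group or a carboxylic acid, lie outside the compounds shown. On these data alone, the reading for a double bond drawn Z also remains open.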